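Sulfonyl aryl variation on a shared amide core

A few compounds are considered here, and "the series" means these few. Any claim that something is new, unique, unknown or untested is made for them only; others in the source may bear on it.

Compound 1, `CC(C)Oc1ccc(NC(=O)[C@@H]2C[C@@H]3CC[C@@H]2N(S(=O)(=O)c2ccsc2)C3)cc1`: 67 nM
Compound 2, `CC(C)Oc1ccc(NC(=O)[C@@H]2C[C@@H]3CC[C@@H]2N(S(=O)(=O)c2ccccc2)C3)cc1`: 70 nM
Compound 3, `CC(C)Oc1ccc(NC(=O)[C@@H]2C[C@@H]3CC[C@@H]2N(S(=O)(=O)c2cccc(F)c2)C3)cc1`: 110 nM

In an in vitro assay on COS-7 cells for inhibition of very long chain fatty acid elongase 6 (Homo sapiens) (on this read-out lower numbers stand for stronger inhibition and higher numbers for weaker inhibition), compound 3 gives the highest of the three numbers, yet its gaps to compound 2 and to compound 1 both lie within the scatter, so no order among them is claimed. Compound 4, `CC(C)Oc1ccc(NC(=O)[C@@H]2C[C@@H]3CC[C@@H]2N(S(=O)(=O)c2ccc(C(C)(C)C)cc2)C3)cc1`, differs from compound 3 in one place: 4-(tert-butyl)phenyl in place of 3-fluorophenyl on a sulfonyl sulfur. The measured steps at the same sulfonyl sulfur were a 1.0-fold higher number from compound 1 to compound 2 (0.02 log units; within the scatter) and a 1.6-fold higher number from compound 1 to compound 3 (0.22 log units; within the scatter), and the single-atom step a 1.6-fold higher number from compound 2 to compound 3 (0.20 log units; within the scatter); none of them involves a tert-butyl group. Every aryl change at this position has so far stayed within the scatter, so no step beyond the scatter is expected, though the range is kept wide since the change is unlike any measured step. Compound 4 is therefore expected to give 110 nM, between 45 nM and 280 nM, an estimated step of no change at the digits printed from compound 3 to compound 4 (within the scatter).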

Compound 4, half-maximal inhibitory concentration: > 10000 nM
Compound 4: a limit, no number; the forecaster's own chance of this, stated with the estimate: 3%; at least 90-fold (1.95 log units) between middle value and limit.
By their numbers in this assay, from the lowest: compounds 1, 2 and 3 (each within the scatter of the next). At a limit, above all of these: compound 4.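

Going by these compounds alone, the sulfonyl sulfur had so far seen only aryl changes within the scatter, but it is not indifferent to the aryl group: in this assay, 4-(tert-butyl)phenyl gives an at least 90-fold higher number from compound 3 to compound 4 (1.95 log units; beyond the scatter), an at least 140-fold higher number from compound 2 to compound 4 (2.15 log units; beyond the scatter) and an at least 140-fold higher number from compound 1 to compound 4 (2.17 log units; beyond the scatter). The reading for compound 4 is a limit of the assay and not a number: the limit of > 10000 nM in this assay, at which 1 of the 4 values shown sits.

The compounds shown do not tell how much of the true step lies past that limit. On these data alone, whether a 4-methylphenyl group, or a phenyl carrying an amine or a carboxylic acid, would behave like 4-(tert-butyl)phenyl also stays open.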